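Working notes on compounds 1, 2 and 3

The source may hold more compounds than are shown below. What is called first, only, known or untested is meant among the compounds shown, and "the series" means these compounds.

Two compounds carry numbers in a functional assay on cells (Cancer cell lines, Homo sapiens) for cytotoxicity, with a stated time of 48 h; a lower number here means a stronger inhibitor of growth, a higher number a weaker inhibitor of growth. Compound 1 `COc1cc2c(/C=C3/C(=O)Nc4ccc(O)cc43)c(Cl)n(Cc3cc(OC)c(OC)c(OC)c3)c2cc1C` gives 2750 nM there. Compound 2 `O=C1/C(=C/c2c(Cl)[nH]c3ccccc23)c2ccccc2N1Cc1ccccc1` gives 5250 nM in this assay. On the numbers alone compound 1 stands at the low end of the pair, but its nearest neighbour is compound 2 and the gap between the two lies within the usual scatter, so the two values do not separate. Going by the values given here, compound 2 differs from compound 1 in several places at once, so its pair with compound 1 yields only these two values and no single-change step.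

Compound 3 `COc1cc2c(/C=C3/C(=O)Nc4cccc(Cl)c43)c(Cl)n(Cc3cc(OC)c(OC)c(OC)c3)c2cc1C` has not been measured in this assay. It differs from compound 1 by a group of 12 heavy atoms (9 carbon, 1 nitrogen, 1 oxygen, 1 chlorine; one five-membered non-aromatic ring with 1 hetero atom, one six-membered aromatic ring of carbon only) in place of a group of 12 heavy atoms (9 carbon, 1 nitrogen, 2 oxygen; one five-membered non-aromatic ring with 1 hetero atom, one six-membered aromatic ring of carbon only), on an aromatic carbon. Among the compounds with values here, no single-change step between measured compounds exists to guide this change, so nothing in the data points to a direction. The step from compound 1 to compound 3 is therefore expected to be a 1.1-fold higher number from compound 1 to compound 3 (0.04 log units; within the scatter), that is, no change beyond the scatter. Compound 3 is estimated at 3000 nM in this assay, with a range from 1000 nM to 9000 nM.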

Compound 3, concentration for 50% growth inhibition: 3240 nM
Compound 3: middle estimate off by 1.1-fold (0.03 log units), on the low side; measured number inside the range.
By their numbers in this assay, from the lowest: compounds 1, 3 and 2 (each within the scatter of the next).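

Going by these compounds alone, this is the first single-change step at this position, on an aromatic carbon of a five-membered aromatic ring with 1 nitrogen, next to the ring atom that bears a chloro group, and in this assay it reads as a 1.2-fold higher number from compound 1 to compound 3 (0.07 log units; within the scatter) for the exchange of the whole group of 12 heavy atoms. In this pair, the group with 1 chlorine, 1 hydrogen-bond donor and 1 hydrogen-bond acceptor takes the place of the group with 2 oxygen, 2 hydrogen-bond donors and 2 hydrogen-bond acceptors without a change beyond the scatter, so the loss of that oxygen-bearing arrangement does not register in this read-out. No measurement on hand bears on why the two groups read alike.

All three compounds still lie within the scatter of one another, so no group at this position has yet been seen to move the number in either direction. From the compounds shown here alone, it remains open whether a group carrying an amine or a carboxylic acid in this place would give a step beyond the scatter, and a single pair says nothing about how far this flat reading extends.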